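The compounds below may be only part of what the source reports. "The series", "measured", "known", "first", "only" and "open" are said of these compounds alone.

Going by the values given here, compound 3 `N#C[Se]c1ccc(NC(=O)Oc2ccc(Cl)cc2)cc1` is one of three compounds measured so far in a functional assay on CCRF-CEM cells (Homo sapiens) for cytotoxicity, read by MTT assay, with a stated time of 72 h; on this read-out higher numbers stand for weaker inhibition of growth and lower numbers for stronger inhibition of growth. In this assay compound 3 gives 18300 nM, the highest of the three numbers. Compound 1 `CCCOC(=O)Nc1ccc([Se]C#N)cc1` in this assay gives 9300 nM, and compound 2 `CC(C)COC(=O)Nc1ccc([Se]C#N)cc1` in this assay gives 9300 nM; each of these differs from compound 3 only within the scatter, so no order among the three can be read from these numbers. Among the compounds with values here, the single step between measured compounds that differ in one place, no change at the digits printed from compound 1 to compound 2 (within the scatter), concerns a methyl in place of hydrogen on a saturated chain carbon and leaves the aromatic rings untouched.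

Compound 4 `N#C[Se]c1ccc(NC(=O)Oc2ccccc2)cc1` differs from compound 3 by hydrogen in place of chloro on an aromatic carbon. Within the data shown here, no measured step bears directly on this change, as the only step available is on a saturated chain rather than on an aromatic carbon. With nothing in the measured compounds pointing in either direction, no step beyond the scatter is expected, and compound 4 is estimated to show a 1.2-fold lower number from compound 3 to compound 4 (0.09 log units; within the scatter) relative to compound 3. On this basis compound 4 is expected to give about 15000 nM in this assay, with a range from 6000 nM to 40000 nM.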

Compound 4, concentration for 50% growth inhibition: 22900 nM
For compound 4 the middle estimate is 1.5-fold (0.18 log units) below the measured one; the range from low to high includes it.
By their numbers in this assay, from the lowest: compounds 1, 2, 3 and 4 (each within the scatter of the next, the first and the last beyond it).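

In this assay, the aromatic carbon para to a large group now has a step of its own: hydrogen in place of chloro gives a 1.3-fold higher number from compound 3 to compound 4 (0.10 log units; within the scatter), so at this position, the loss of the chloro does not separate the two compounds. Going by these compounds alone, the oxygen next to a carbonyl group shows something the earlier compounds could not, namely a step beyond the scatter: phenyl in place of propyl gives a 2.5-fold higher number from compound 1 to compound 4 (0.39 log units; beyond the scatter), and phenyl in place of isobutyl gives a 2.5-fold higher number from compound 2 to compound 4 (0.39 log units; beyond the scatter), both modest and both toward weaker inhibition of growth. Nothing at hand offers an explanation for either the small step on the ring or the modest steps on the oxygen.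

The compounds shown leave open whether another group on this aromatic carbon, such as methoxy, an amine or a carboxylic acid, would also stay within the scatter of hydrogen and chloro. They also leave open how a benzyl group or a longer chain on the oxygen next to the carbonyl group would compare with the propyl, isobutyl and phenyl groups.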